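Working notes: removing the chloro from compound 3

The source may report more compounds than this note shows. Statements on the series, on what has been measured and on what is new or still open speak of the compounds shown alone.

Measured so far:
compound 1, `O=C(Nc1cccc(-n2cc(-c3ccncc3)c(-c3cc(O)cc(Cl)c3)n2)c1)Nc1ccc(Cl)c(C(F)(F)F)c1`: 21.5%
compound 2, `O=C(Nc1cccc(-n2cc(-c3ccncc3)c(-c3cc(O)cc(Cl)c3)n2)c1)Nc1ccc(Cl)c(Cl)c1`: -2.98%
compound 3, `COc1cc(Cl)cc(-c2nn(-c3cccc(NC(=O)Nc4ccc(Cl)c(C(F)(F)F)c4)c3)cc2-c2ccncc2)c1`: -9.18%

In a functional assay on A498 cells (Homo sapiens) for inhibition, read by sulforhodamine B assay, with a stated time of 48 h, tested at 10 uM (a higher number here means a weaker effect of the compound at the concentration tested, a lower number a stronger effect), compound 3 has the lowest of the three numbers; its gap to compound 2 lies within the scatter, its gap to compound 1 does not. Compound 4, `COc1cc(Cl)cc(-c2nn(-c3cccc(NC(=O)Nc4cccc(C(F)(F)F)c4)c3)cc2-c2ccncc2)c1`, differs from compound 3 in one place: hydrogen in place of chloro on an aromatic carbon. For the measured compounds named here, of the measured steps, a number 24.5 percentage points lower from compound 1 to compound 2 (beyond the scatter) and a number 30.7 percentage points lower from compound 1 to compound 3 (beyond the scatter) each alter a different group, so neither bears directly on taking away this chloro; the series offers no comparable step. Since compound 3 sits near the floor of the read-out, only a modest upward drift is expected, a number 14.2 percentage points higher from compound 3 to compound 4 (beyond the scatter). For compound 4 the estimate is 5%, within -15% to 35%.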

Compound 4, a percentage reported as activity, at one concentration (the size of the read-out at that concentration, not a potency): -6.74%
Estimate against measurement, compound 4: 11.7 percentage points above, and the stated range covers the measured number.
By their numbers in this assay, from the lowest: compounds 3, 4 and 2 (each within the scatter of the next); then compound 1.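

In this assay, for the compounds shown here, taking away the chloro gives a number 2.4 percentage points higher from compound 3 to compound 4 (within the scatter), the first step to alter this position. With the methyl on the oxygen in place, the 3-(trifluoromethyl)phenyl group therefore reads the same as the 4-chloro-3-(trifluoromethyl)phenyl group, so this chloro is not needed for the effect at the concentration tested. No measurement here gives a cause for this result.

Open, as far as these compounds go, is whether an amine or a carboxylic acid on this carbon would shift the number. Also open, from the compounds shown here alone, is whether removing the chloro from compound 1, which has the free hydroxyl, would read the same way.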